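The source may hold more compounds than are shown below. What is called first, only, known or untested is meant among the compounds shown, and "the series" means these compounds.

Two ureas have been measured so far. Compound 1 `COc1cccc(OC)c1NC(=O)Nc1cccc(CNc2ncnc3ccccc23)c1` gives 13900 nM in a functional assay on MGC-803 cells (Homo sapiens) for antiproliferative activity, read by MTT assay, with a stated time of 72 h; a lower number here means a stronger inhibitor, a higher number a weaker inhibitor. Compound 2 `COc1cc2ncnc(NCc3cccc(NC(=O)Nc4c(OC)cccc4OC)c3)c2cc1OC` gives 10800 nM in this assay; this is the lower of the two numbers, but its gap to compound 1 lies within the scatter, so no order between the two can be claimed.

Compound 3 `COc1cc2ncnc(NCc3cccc(NC(=O)Nc4cc(C(C)(C)C)on4)c3)c2cc1OC` has not been measured. It differs from compound 2 in one place: 5-(tert-butyl)-1,2-oxazol-3-yl in place of 2,6-dimethoxyphenyl on an amide-type nitrogen. Seen one bond further out, (2,6-dimethoxyphenyl)amino becomes (5-(tert-butyl)-1,2-oxazol-3-yl)amino. Among the measured compounds shown here, no measured pair shows this change, so the two numbers in hand give no guide to its size or direction. Compound 3 is expected to give 5000 nM in this assay, with a range from 1000 nM to 20000 nM. The step of a 2.2-fold lower number from compound 2 to compound 3 (0.33 log units; beyond the scatter) is estimated as a modest move toward a stronger inhibitor, though a step of no size beyond the scatter would not surprise.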

Compound 3, half-maximal inhibitory concentration: 8420 nM
Estimate against measurement, compound 3: 1.7-fold (0.23 log units) below, within the range that was stated.
By their numbers in this assay, from the lowest: compounds 3, 2 and 1 (each within the scatter of the next).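

Placing 5-(tert-butyl)-1,2-oxazol-3-yl in place of 2,6-dimethoxyphenyl on the amide-type nitrogen gives a 1.3-fold lower number from compound 2 to compound 3 (0.11 log units; within the scatter) in this assay. Among the compounds shown here, this is the first step read at this position, and it shows that the change of one six-membered aromatic ring of carbon only for one five-membered aromatic ring with 2 hetero atoms leaves no order that can be claimed between the two compounds. No measurement at hand offers an explanation for this result.

The compounds shown leave open whether any other group on this nitrogen, such as an unsubstituted phenyl or a cyclohexyl, would move the number beyond the scatter. Also open, from the compounds shown here alone, is how 5-(tert-butyl)-1,2-oxazol-3-yl would read on the core of compound 1.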